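Swapping methoxy for methylsulfanyl on a weakly active series

A few compounds are considered here, and "the series" means these few. Any claim that something is new, unique, unknown or untested is made for them only; others in the source may bear on it.

Measured in a functional assay on HeLa cells (Homo sapiens) for inhibition, read by MTT assay, with a stated time of 48 h; a higher number here means a weaker inhibitor, a lower number a stronger inhibitor:
Compound 1 `Cc1ccc(-c2nc3ccccn3c2Sc2ccccc2)cc1`: 86700 nM
Compound 2 `COc1ccc(-c2nc3ccccn3c2Sc2ccccc2)cc1`: > 100000 nM

Compound 2 gives > 100000 nM, which is a limit of the assay and not a number. As far as these compounds go, its true position therefore stays unknown on these data.

Going by the values given here, the one measured step that bears on the next change is methoxy in place of methyl on an aromatic carbon, which gave an at least 1.1-fold higher number from compound 1 to compound 2 (0.06 log units; that floor lies within the scatter). From the compounds shown here alone, only a floor is known for that step, so its real size remains open.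

Compound 3 `CSc1ccc(-c2nc3ccccn3c2Sc2ccccc2)cc1` has not yet been measured. It carries methylsulfanyl in place of methoxy on an aromatic carbon, para to a large group: methylsulfanyl in place of methoxy on an aromatic carbon. Among the compounds with values here, the change touches the same place as the measured step, and compound 1 at 86700 nM is the only firm number nearby. No step beyond the scatter is therefore expected in this assay, and compound 3 may also end at the limit.

The estimated step is an at least 1.1-fold lower number from compound 2 to compound 3 (0.04 log units; that floor lies within the scatter). For compound 3 the estimate is 90000 nM, with an expected range of 40000 nM to 150000 nM.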

Compound 3, half-maximal inhibitory concentration: 30000 nM
For compound 3 the middle estimate is 3.0-fold (0.48 log units) above the measured one, and the stated range ends above it.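

In this assay, the place on the aromatic ring para to a large group now shows that it can respond to a change of a single group, since methylsulfanyl in place of methoxy gives an at least 3.3-fold lower number from compound 2 to compound 3 (0.52 log units; beyond the scatter). The earlier step between methyl and methoxy could only be read as a floor inside the scatter, whereas methylsulfanyl in place of methyl gives a 2.9-fold lower number from compound 1 to compound 3 (0.46 log units; beyond the scatter), a step between two real numbers and so the firmest size available at this position, which makes compound 3 the strongest of the three compounds. The step involving methoxy still has no true size, as compound 2 remains at a limit of the assay and not at a number: the limit of > 100000 nM in this assay, at which 1 of the 3 values shown sits.

Open, as far as these compounds go, is whether this place would respond further to other sulfur-bearing groups, such as ethylsulfanyl or methylsulfonyl, or to a quite different group, such as an amine or a carboxylic acid. Going by these compounds alone, also open is whether methylsulfanyl in place of methoxy would give a similar step on a core other than the one shared by these compounds.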